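Swapping an octyl chain for phenyl on the ring amide

The source may hold more compounds than are shown below. What is called first, only, known or untested is meant among the compounds shown, and "the series" means these compounds.

Compound 3 `CCCCCCCCC(=O)N1c2ccccc2CCC1C(=O)Nc1ccccc1O` carries a long acyl group on the ring nitrogen of the shared core. In a functional assay on HCT-15 cells (Homo sapiens) for cytotoxicity, read by sulforhodamine B assay, with a stated time of 72 h (a higher number here means a weaker inhibitor of growth, a lower number a stronger inhibitor of growth), compound 3 gives 38400 nM, the second highest of the three numbers measured. For the measured compounds named here, its closest neighbour is compound 1 `CC(=O)N1c2ccccc2CCC1C(=O)Nc1ccccc1O`, which in this assay gives 54500 nM; the only single-point step measured, a 1.4-fold lower number from compound 1 to compound 3 (0.15 log units; within the scatter), shows that lengthening the acyl chain by heptyl in place of hydrogen changed little. Compound 2 `O=C(Nc1ccccc1C(F)(F)F)C1CCc2ccccc2N1C(=O)c1ccccc1`, which carries a benzoyl group and a trifluoromethyl-bearing anilide, gives 6500 nM, a clearly lower number than compound 3, though two parts of the molecule differ at once.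

Compound 4 `O=C(Nc1ccccc1O)C1CCc2ccccc2N1C(=O)c1ccccc1` differs from compound 3 in one place: phenyl in place of octyl on a carbonyl carbon. Going by the values given here, no measured step isolates this change. Among the compounds with values here, the only hint is that compound 2, the one benzoyl compound, gives 6500 nM, so a modestly lower number is expected, with wide uncertainty; the expected step is a 1.9-fold lower number from compound 3 to compound 4 (0.28 log units; within the scatter). Compound 4 is estimated at 20000 nM, within a range from 6000 nM to 60000 nM.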

Compound 4, concentration for 50% growth inhibition: 3830 nM
The estimate for compound 4 lay 5.2-fold (0.72 log units) above the measured number, outside the stated range (below it).
By their numbers in this assay, from the lowest: compounds 4 and 2 (each within the scatter of the next); then compounds 3 and 1 (each within the scatter of the next).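

In this assay the group on the carbonyl carbon bound to the amide-type nitrogen in a ring matters more than the earlier chain change suggested: phenyl in place of octyl gives a 10-fold lower number from compound 3 to compound 4 (1.00 log units; beyond the scatter) and phenyl in place of methyl gives a 14-fold lower number from compound 1 to compound 4 (1.15 log units; beyond the scatter) while lengthening the chain alone gave only a 1.4-fold lower number from compound 1 to compound 3 (0.15 log units; within the scatter) within the scatter. Among these compounds, then, the benzoyl group sets the lower numbers apart, and chain length does not. With benzoyl present, hydroxy in place of trifluoromethyl on an aromatic carbon gives a 1.7-fold lower number from compound 2 to compound 4 (0.23 log units; within the scatter) so the two groups cannot be told apart here.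

Nothing measured here explains why phenyl differs from the chains. From the compounds shown here alone, whether a cyclohexyl or pyridine ring in place of phenyl would give a similarly low number remains open.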